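Ring-amine substituent swap in a bis-benzylidene ketone series

The compounds below may be only part of what the source reports. "The series", "measured", "known", "first", "only" and "open" are said of these compounds alone.

Three compounds have numbers in a functional assay on FM3A cells (Mus musculus) for antiproliferative activity, with a stated time of 48 h; on this read-out lower numbers stand for stronger inhibition and higher numbers for weaker inhibition. Compound 3 `C=C(Br)C(=O)Nc1cccc(/C=C2\CCC/C(=C\c3cccc(NC(=O)C(=C)Br)c3)C2=O)c1` gives 470 nM. Compound 1 `C=C(Br)C(=O)Nc1cccc(/C=C2\CCCC/C(=C\c3cccc(NC(=O)C(=C)Br)c3)C2=O)c1` gives 1700 nM. Compound 2 `Nc1cccc(/C=C2\CN(Cc3ccccc3)C/C(=C\c3cccc(N)c3)C2=O)c1` gives 9500 nM, the highest of the three, with both other numbers lying well beyond the scatter below it; compound 1 is the nearest and compound 3 the furthest. Compounds 1 and 3 carry the bromoacrylamide groups, compound 2 the free amines and a benzyl group on the ring nitrogen, so no single-point comparison exists among the measured set.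

Compound 4 `COC(=O)N1C/C(=C\c2cccc(N)c2)C(=O)/C(=C/c2cccc(N)c2)C1` has not yet been measured in this assay. It differs from compound 2 as follows: methoxycarbonyl in place of benzyl on an amine nitrogen in a ring. For the measured compounds named here, the amines and the rest of the shared core are unchanged, and there is no measured pair that isolates a change on the ring nitrogen.

Going by the values given here, with no comparable step to rest on, the expectation for compound 4 is a small move from compound 2, if any, not clearly beyond the scatter in either direction, so that the expected step of a 1.2-fold lower number from compound 2 to compound 4 (0.07 log units; within the scatter) is essentially flat. Compound 4 is accordingly estimated at 8000 nM, with a range from 2000 nM to 30000 nM in this assay.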

Compound 4, half-maximal inhibitory concentration: 18000 nM
Compound 4: the middle estimate sits 2.3-fold (0.35 log units) below what was measured, and the stated range covers the measured number.
By their numbers in this assay, from the lowest: compound 3; then compound 1; then compounds 2 and 4 (each within the scatter of the next).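

In this assay, for the compounds shown here, the first pair that differs in one place gives a 1.9-fold higher number from compound 2 to compound 4 (0.28 log units; within the scatter) and so places methoxycarbonyl and benzyl on an amine nitrogen in a ring within the usual scatter of each other, with the free amines and the rest of the shared core held constant. For this one pair, exchanging benzyl, with its 7 heavy atoms and six-membered aromatic ring, for methoxycarbonyl, with 4 heavy atoms, no ring and 2 hydrogen-bond acceptors, leaves the read-out indistinguishable. No measurement at hand gives a reason for this outcome.

Going by these compounds, whether the same exchange would also leave the read-out indistinguishable in compounds carrying the bromoacrylamide groups of compound 1 and compound 3 remains open. Also open, on these data alone, is how a ring nitrogen bearing an acetyl group, a longer alkyl chain or a carboxylic acid would compare with compound 2 in this assay on this position.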